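Amide nitrogen substituent: compound 2 to compound 3

A few compounds are considered here, and "the series" means these few. Any claim that something is new, unique, unknown or untested is made for them only; others in the source may bear on it.

Going by the values given here, in an ADME assay on MT4 cells (Homo sapiens) for cytotoxicity, read by MTT assay (a higher number here means that more compound is tolerated, a lower number that less compound is tolerated), compound 2 (`Cc1cc(C)cc(S(=O)(=O)c2c(C(=O)NC(C)c3cccnc3)[nH]c3ccc(Cl)cc23)c1`) gives 54600 nM, the highest of the two numbers so far, while compound 1 (`Cc1cc(C)cc(S(=O)(=O)c2c(C(=O)Nc3ccncc3)[nH]c3ccc(Cl)cc23)c1`) gives 20200 nM. The next change leads to compound 3 (`Cc1cc(C)cc(S(=O)(=O)c2c(C(=O)NCc3ccco3)[nH]c3ccc(Cl)cc23)c1`): (furan-2-yl)methyl in place of 1-(pyridin-3-yl)ethyl on an amide-type nitrogen. In words, this is (furan-2-yl)methyl in place of 1-(pyridin-3-yl)ethyl on an amide-type nitrogen. Among the compounds with values here, one measured step bears on it, a 2.7-fold higher number from compound 1 to compound 2 (0.43 log units; beyond the scatter), a modest change at the same nitrogen with the shared core untouched. Within the data shown here, no measured compound carries the (furan-2-yl)methyl group, so that step is the only guide to size. With compound 2 at the top of the two numbers at 54600 nM, a step no larger than that one is expected, more likely down than up. The expected change is a 1.7-fold lower number from compound 2 to compound 3 (0.23 log units; within the scatter). Compound 3 is estimated at 32000 nM, with an expected range of 13000 nM to 75000 nM.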

Compound 3, half-maximal cytotoxic concentration: > 56400 nM
Compound 3 ended at the assay's limit; the forecaster's own chance of this, stated with the estimate: 15%; middle value at least 1.7-fold (0.24 log units) from the limit.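

In this assay, compound 3 gives a limit and not a number: the limit of > 56400 nM in this assay, at which 1 of the 3 values shown sits.

The swap of 1-(pyridin-3-yl)ethyl for (furan-2-yl)methyl gives an at least 1.0-fold higher number from compound 2 to compound 3 (0.01 log units; that floor lies within the scatter), so this floor does not order the two groups at the amide-type nitrogen. The comparison with the pyridin-4-yl group is clearer, at an at least 2.7-fold higher number from compound 1 to compound 3 (0.44 log units; beyond the scatter), and shows that a pyridine ring on this nitrogen is not required for a high number in this assay.

From the compounds shown here alone, how far compound 3 lies past its limit remains open, as does any ranking among the groups that reach the top of the range. Also open, going by these compounds, is whether the same tolerance holds for a longer alkyl chain, an aminoethyl chain or a carboxylic acid on this nitrogen.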